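Pyridin-3-yl in place of 2-fluorophenyl: notes on compound 3

A few compounds are considered here, and "the series" means these few. Any claim that something is new, unique, unknown or untested is made for them only; others in the source may bear on it.

Values so far in an ADME assay (liver) for metabolic stability, with Liver microsome (Homo sapiens) as the target, using microsomes; a higher number here means faster removal of the compound, a lower number slower removal
- compound 1 `c1ccc(CNc2nnc(-c3nc4ccncc4s3)o2)cc1` gives 23 mL.min-1.g-1
- compound 2 `Fc1ccccc1CNc1nnc(-c2c[nH]c3ncccc23)o1` gives 32 mL.min-1.g-1

Compound 2 stands at 32 mL.min-1.g-1 in this short series, and its gap to compound 1 lies within the scatter, so the two numbers do not separate. The next structure is compound 3 (`c1cncc(CNc2nnc(-c3c[nH]c4ncccc34)o2)c1`), which keeps the core of compound 2 and carries pyridin-3-yl in place of 2-fluorophenyl on a saturated chain carbon bound to a nitrogen on an aromatic ring. Within the data shown here, no pair of measured compounds isolates this change, so the range is kept wide. In this assay a small downward move is expected, with a 1.6-fold lower number from compound 2 to compound 3 (0.20 log units; within the scatter) as the estimate, and that size stays within the scatter. The estimated value for compound 3 is 20 mL.min-1.g-1 (expected range 9 mL.min-1.g-1 to 42 mL.min-1.g-1).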

Compound 3, intrinsic clearance in microsomes: < 14 mL.min-1.g-1
Compound 3: a limit, no number (the forecaster's own chance of this, stated with the estimate: 5%); at least 1.4-fold (0.15 log units) between middle value and limit.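

In this assay, among these compounds, this is the first change that can be read in one place: pyridin-3-yl in place of 2-fluorophenyl on a saturated chain carbon bound to a nitrogen on an aromatic ring gives an at least 2.2-fold lower number from compound 2 to compound 3 (0.35 log units; beyond the scatter). Among the compounds shown here, compound 1 and compound 2 differ in more than one place and offered no such step. The step is a minimum and its full size stays unknown, with compound 3 reading as a limit and not a number: the limit of < 14 mL.min-1.g-1 in this assay, at which 1 of the 3 values shown sits.

Still open is whether the step follows the ring nitrogen entering or the fluorine leaving; no compound shown carries plain phenyl at this place on the core of compound 2. Also open, on these data alone, is how a saturated ring such as cyclohexyl, or a pyridin-4-yl, would read at the same place.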